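Chloro Added to an Aryl Triazole Tested in Mice

The source may report more compounds than this note shows. Statements on the series, on what has been measured and on what is new or still open speak of the compounds shown alone.

Compound 3, with the structure `CC(=O)n1nc(-c2ccccc2)nc1C`, is one of three compounds examined in a functional assay on the whole organism with Mus musculus as the target; a lower number here means that less compound is needed, a higher number that more compound is needed for the effect. Compound 3 gives 439 mg/kg in this assay, the only result that is an actual number. Compound 1, with the structure `CCc1nnc(CC)n1N`, reaches only a limit of the assay, > 600 mg/kg. Compound 2, with the structure `CCc1nnc(CC)n1/N=C(\N)c1ccc(Cl)cc1`, likewise stops at a limit of the assay, > 600 mg/kg. So the limit of > 600 mg/kg in this assay, at which 2 of the 3 values shown sit, marks where two of the three results sit, and compound 3 stands apart from it as the one compound with a measured dose.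

Compound 4, with the structure `CC(=O)n1nc(-c2ccc(Cl)cc2)nc1C`, has not yet been measured. It differs from compound 3 in one place: chloro in place of hydrogen on an aromatic carbon. Among the measured compounds shown here, no pair of measured compounds differs in this single way, so there is no measured step to lean on. The step expected in this assay is a 1.1-fold lower number from compound 3 to compound 4 (0.04 log units; within the scatter), a change no larger than the scatter of repeated measurements, in either direction. On that basis compound 4 is expected to give about 400 mg/kg in this assay, within a range from 200 mg/kg to 800 mg/kg.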

Compound 4, dose for 50% inhibition: 342 mg/kg
Beside the measured number, compound 4's estimate is 1.2-fold (0.07 log units) above it; the range from low to high includes it.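

Chloro in place of hydrogen on an aromatic carbon, para to a group of 9 heavy atoms, is the first change here that can be read as a step between two measured doses: in this assay, the step is a 1.3-fold lower number from compound 3 to compound 4 (0.11 log units; within the scatter). A step of this size does not separate the two compounds, so this single added chlorine atom on the six-membered aromatic ring leaves the dose needed for the effect indistinguishable from that of the parent compound. The earlier compounds could not show this, as only one of them had an actual number and the others gave only a limit of the assay, which is where the second new comparison cannot reach: the limit of > 600 mg/kg in this assay, at which 2 of the 4 values shown sit.

The compounds shown leave open whether another group at this same place, such as methoxy, an amine or a carboxylic acid, would move the dose beyond the usual scatter. Among the compounds shown here, they also leave open whether chloro elsewhere on the ring would behave as it does here, since this one step is the only reading of the change.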